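Arylpiperazine ureas: working notes

A few compounds are considered here, and "the series" means these few. Any claim that something is new, unique, unknown or untested is made for them only; others in the source may bear on it.

Measured so far:
compound 1 `COCC1=C(C(=O)OC)C(c2cc(F)c(F)cc2F)N(C(=O)NCCCN2CCN(c3ccccc3C(N)=O)CC2)C(=O)N1`: in an assay on liver for binding affinity to Alpha-1A adrenergic receptor (Homo sapiens), using microsomes (a lower number here means a stronger inhibitor, a higher number a weaker inhibitor), compound 1 gives 0.1 nM
compound 2 `COC(=O)C1=C(C)NC(=O)N(C(=O)NCCCN2CCN(c3ccccc3Cl)CC2)C1c1ccc(F)c(F)c1`: compound 2 gives 0.2 nM
compound 3 `CC(=O)C1=C(C)NC(=O)N(C(=O)NCCCN2CCN(c3ccccc3C(N)=O)CC2)C1c1ccc(F)c(F)c1`: compound 3 gives 0.7 nM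

Compound 2 holds the second highest of the three numbers in this assay. Its nearest neighbour is compound 1, whose number is lower by an amount within the usual scatter, so no order between compound 1 and compound 2 can be read from these two values. The furthest is compound 3, whose number is higher by an amount beyond the scatter; of that pair, compound 3 is the weaker binder.

Compound 4 `COC(=O)C1=C(C)NC(=O)N(C(=O)NCCCN2CCN(c3cccc([N+](=O)[O-])c3)CC2)C1c1ccc(F)c(F)c1` has not been measured. It differs from compound 2 in one place: 3-nitrophenyl in place of 2-chlorophenyl on an amine nitrogen in a ring. Within the data shown here, no measured compound carries a 3-nitrophenyl on the ring amine nitrogen, so there is no anchored step to lean on; all three measured compounds keep a group of the kind seen in compound 2 at that position, and the change takes the series outside that set.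

The step expected from compound 2 to compound 4 is a 7.5-fold higher number from compound 2 to compound 4 (0.88 log units; beyond the scatter), toward a higher number, probably beyond the scatter but with wide uncertainty. Compound 4 is accordingly estimated at 1.5 nM, within a range of 0.3 nM to 8 nM.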

Compound 4, inhibition constant: 12 nM
Compound 4: the middle estimate sits 8.0-fold (0.90 log units) below what was measured; measured number outside the range, above it.
By their numbers in this assay, from the lowest: compounds 1 and 2 (each within the scatter of the next); then compound 3; then compound 4.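

In this assay, the aryl group on the ring amine nitrogen strongly affects the measured affinity: exchanging 2-chlorophenyl for 3-nitrophenyl gives a 60-fold higher number from compound 2 to compound 4 (1.78 log units; beyond the scatter), with the rest of the molecule unchanged. Among these compounds, this is the first single-place step, and it shows that this position can tolerate far less change than the closely spaced values of the earlier compounds could reveal. The exchange alters both the substituent and where it sits on the phenyl ring, and nothing available explains the size of the step or divides it between those two changes.

On these data alone, it remains open whether the step comes from losing the chlorine, gaining the nitro group or moving the substituent, and a plain phenyl or an aminophenyl on the same nitrogen would help to separate these. Whether a step of this size would recur on the core of compound 1 or compound 3 is also unresolved.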